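This account rests on a few compounds, and the source may have more. Where it says the series, first, only, none or still open, it means among the compounds named here.

Measured in a functional assay for antagonist activity at Alpha-1A adrenergic receptor (Oryctolagus cuniculus); on this read-out lower numbers stand for tighter binding and higher numbers for weaker binding:

compound 1 `CCOc1ccccc1N1CCN(CCCNc2ncccc2C(=O)N(C)C)CC1`: 0.501 nM
compound 2 `CN(C)C(=O)c1cccnc1NCCCN1CCN(c2ccccc2-c2ncco2)CC1`: 0.316 nM
compound 3 `CN(C)C(=O)c1cccnc1NCCCN1CCN(c2ccccc2Cc2ccccc2)CC1`: 6.31 nM

Compound 1 holds the second highest of the three numbers in this assay. Its nearest neighbour is compound 2, reached by a 1.6-fold lower number from compound 1 to compound 2 (0.20 log units; within the scatter), a step that stays within the scatter. Its furthest is compound 3, reached by a 13-fold higher number from compound 1 to compound 3 (1.10 log units; beyond the scatter), a large step; the related step of a 20-fold higher number from compound 2 to compound 3 (1.30 log units; beyond the scatter) is large as well.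

The unmeasured compound 4 `COc1cc(C)ccc1N1CCN(CCCNc2ncccc2C(=O)N(C)C)CC1` differs from compound 1 in one place: 2-methoxy-4-methylphenyl in place of 2-ethoxyphenyl on an amine nitrogen in a ring. For the measured compounds named here, the only measured steps that touch this part of the shared core are the exchanges of ethoxy for 1,3-oxazol-2-yl and for benzyl. The first of those left the number within the scatter; the second, which brought in a second ring of carbon only, raised it a great deal. The group entering in compound 4 keeps one hydrogen-bond acceptor and the same count of heavy atoms as the group that leaves, and brings in no further ring. The step from compound 1 to compound 4 is therefore expected to stay within the scatter, with no clear direction: a 1.2-fold higher number from compound 1 to compound 4 (0.08 log units; within the scatter). In this assay compound 4 is estimated at 0.6 nM, expected to fall between 0.2 nM and 2 nM.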

Compound 4, dissociation constant: 0.794 nM
Estimate against measurement, compound 4: 1.3-fold (0.12 log units) below, within the range that was stated.
By their numbers in this assay, from the lowest: compounds 2, 1 and 4 (each within the scatter of the next, the first and the last beyond it); then compound 3.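

In this assay, the step of a 1.6-fold higher number from compound 1 to compound 4 (0.20 log units; within the scatter) shows that the group on an amine nitrogen in a ring can be rearranged, with 2-methoxy-4-methylphenyl in place of 2-ethoxyphenyl, and the read-out stays within the scatter. The earlier steps shown here at this part of the molecule each exchanged ethoxy for a group bearing a further ring, and they gave one result within the scatter and one large result, a 13-fold higher number from compound 1 to compound 3 (1.10 log units; beyond the scatter), whereas this step keeps the same atoms, joined differently, and the same count of heavy atoms and hydrogen-bond acceptors. Nothing shown here gives a measured reason for this outcome.

The compounds shown leave open what the methoxy group and the methyl group each do on their own, since the two changes arrive together in compound 4. They also leave open whether a longer alkoxy chain such as propoxy, or a fluorine atom on the same aromatic ring, would likewise keep the number within the scatter of compound 1.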